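Nitro-to-dimethylamino step transferred onto the methylcarbamoyl-phenyl sulfonate

The source may report more compounds than this note shows. Statements on the series, on what has been measured and on what is new or still open speak of the compounds shown alone.

Measured compounds:
compound 1 `O=C(c1ccc([N+](=O)[O-])cc1)N1CCC(n2cncc2-c2ccc(OS(=O)(=O)c3cccc4cnccc34)cc2)CC1`, in an assay on HEK293 cells for antagonist activity at P2X purinoceptor 7 (Homo sapiens), read by fluorescence, with a stated time of 2 h (a higher number here means a weaker inhibitor, a lower number a stronger inhibitor), compound 1 gives 1.49 nM
compound 2 `CN(C)c1ccc(C(=O)N2CCC(n3cncc3-c3ccc(OS(=O)(=O)c4cccc5cnccc45)cc3)CC2)cc1`, compound 2 gives 0.11 nM
compound 3 `CNC(=O)c1cccc(S(=O)(=O)Oc2ccc(-c3cncn3C3CCN(C(=O)c4ccc([N+](=O)[O-])cc4)CC3)cc2)c1`, compound 3 gives 62 nM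

Compound 3 has the highest number of the three. Its core differs from that of compound 1 by 3-(methylcarbamoyl)phenyl in place of isoquinolin-5-yl on a sulfonyl sulfur, a change that made a 42-fold higher number from compound 1 to compound 3 (1.62 log units; beyond the scatter).

Compound 4 `CNC(=O)c1cccc(S(=O)(=O)Oc2ccc(-c3cncn3C3CCN(C(=O)c4ccc(N(C)C)cc4)CC3)cc2)c1` is not yet measured. It differs from compound 3 by dimethylamino in place of nitro on an aromatic carbon. The same change, (dimethylamino in place of nitro on an aromatic carbon), was made from compound 1 to compound 2 and gave a 14-fold lower number from compound 1 to compound 2 (1.13 log units; beyond the scatter). The two place descriptions agree word for word, so the change is the same in both pairs; only the group on the sulfonyl sulfur differs between the two cores.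

For compound 4 a step of about the same size as in the earlier pair is expected, a 14-fold lower number from compound 3 to compound 4 (1.14 log units; beyond the scatter), because that earlier pair gave a 14-fold lower number from compound 1 to compound 2 (1.13 log units; beyond the scatter). Among the measured compounds shown here, whether the step carries over unchanged onto the core of compound 3 is unknown, as only one such pair is measured, so the range is kept wide. Compound 4 is therefore estimated at 4.5 nM, between 1.5 nM and 15 nM.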

Compound 4, half-maximal inhibitory concentration: 25 nM
The estimate for compound 4 lay 5.6-fold (0.74 log units) below the measured number, outside the stated range (above it).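

In this assay, dimethylamino in place of nitro still lowers the number on the core of compound 3, with a 2.5-fold lower number from compound 3 to compound 4 (0.39 log units; beyond the scatter), so the direction of the step carries over but its size does not: the same change on two cores in this assay, a 14-fold lower number (1.13 log units; beyond the scatter) from compound 1 to compound 2 and a 2.5-fold lower number (0.39 log units; beyond the scatter) from compound 3 to compound 4, 5.5-fold (0.74 log units) apart, beyond the scatter of two such steps

Read along the other edge of the same four compounds, 3-(methylcarbamoyl)phenyl in place of isoquinolin-5-yl raises the number further when dimethylamino is present, with a 230-fold higher number from compound 2 to compound 4 (2.36 log units; beyond the scatter), so the two changes do not add independently here: the same change on two cores in this assay, a 42-fold higher number (1.62 log units; beyond the scatter) from compound 1 to compound 3 and a 230-fold higher number (2.36 log units; beyond the scatter) from compound 2 to compound 4, 5.5-fold (0.74 log units) apart, beyond the scatter of two such steps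

Among the compounds shown here, with only one pair on each core, this shows a dependence on the core within these four compounds, but it does not show how the step behaves with other groups on the sulfonyl sulfur, and it gives no reason for the gap.

As far as these compounds go, it remains open whether the larger step is particular to isoquinolin-5-yl or would also appear with a plain phenyl on the sulfonyl sulfur. From the compounds shown here alone, it is also open whether a primary amine or a methoxy group in place of nitro would follow the same core dependence.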